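The compounds below may be only part of what the source reports. "The series", "measured", "known", "first", "only" and "open" are said of these compounds alone.

In a functional assay on NB-4 cells (Homo sapiens) for cytotoxicity, read by CCK-8 assay, with a stated time of 24 h (on this read-out higher numbers stand for weaker inhibition and lower numbers for stronger inhibition), compound 1 `C=CC(=O)N1C(=O)CC(c2ccccc2Cl)Sc2ccccc21` gives 33800 nM, compound 3 `C=CC(=O)N1C(=O)CC(c2ccc(-c3ccccc3)cc2)Sc2ccccc21` gives 57700 nM and compound 2 `C=CC(=O)N1C(=O)CC(c2cccs2)Sc2ccccc21` gives 765000 nM. Compound 3 therefore lies within the scatter of compound 1, and both numbers sit well under that of compound 2. Compound 4 `C=CC(=O)N1C(=O)CC(c2ccc(C#N)cc2)Sc2ccccc21` is still unmeasured. Its change from compound 3 is cyano in place of phenyl on an aromatic carbon. Among the compounds with values here, the one measured single-place step, a 23-fold higher number from compound 1 to compound 2 (1.35 log units; beyond the scatter), is large, but there thiophen-2-yl replaces 2-chlorophenyl on a saturated ring carbon. Compound 4 keeps the six-membered aromatic ring of carbon only, as compound 1 and compound 3 do. The expected step, a 1.2-fold higher number from compound 3 to compound 4 (0.08 log units; within the scatter), stays within the scatter. For compound 4 the estimated value is 70000 nM, with an expected range of 20000 nM to 250000 nM.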

Compound 4, half-maximal inhibitory concentration: 62400 nM
For compound 4 the middle estimate is 1.1-fold (0.05 log units) above the measured one; measured number inside the range.
By their numbers in this assay, from the lowest: compounds 1, 3 and 4 (each within the scatter of the next); then compound 2.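

On this aromatic carbon, phenyl can be swapped for cyano, a group with fewer heavy atoms, without a readable change (a 1.1-fold higher number from compound 3 to compound 4 (0.03 log units; within the scatter)). On the saturated ring carbon, 4-cyanophenyl likewise stays within the scatter of 2-chlorophenyl (a 1.8-fold higher number from compound 1 to compound 4 (0.27 log units; within the scatter)), while the gap from thiophen-2-yl is large (a 12-fold lower number from compound 2 to compound 4 (1.09 log units; beyond the scatter)), so among these four compounds only compound 2 stands apart. No supporting measurement explains this pattern. From the compounds shown here alone, whether an amine or a carboxylic acid on the same aromatic carbon would fit the pattern remains open. So does the effect of a cyclohexyl group on the saturated ring carbon.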